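The compounds below may be only part of what the source reports. "The series", "measured", "known", "first", "only" and "open" are said of these compounds alone.

Three sulfonamides sharing one core have numbers in a functional assay on MDA-MB-231 cells (Homo sapiens) for antiproliferative activity, read by sulforhodamine B assay, with a stated time of 48 h; a higher number here means a weaker inhibitor, a lower number a stronger inhibitor. In this test, compound 1 `Cc1cccc(NS(=O)(=O)c2ccc(N3CCNC3=O)cc2)c1` gives 1270 nM. Compound 2 `O=C1NCCN1c1ccc(S(=O)(=O)Nc2cccc(Br)c2)cc1` has bromo in place of the methyl of compound 1. Compound 2 gives 290 nM, and a 4.4-fold lower number from compound 1 to compound 2 (0.64 log units; beyond the scatter) is a modest step beyond the scatter. Compound 3 `Cc1cc(C)cc(NS(=O)(=O)c2ccc(N3CCNC3=O)cc2)c1`, which carries a 3,5-dimethylphenyl on the sulfonamide nitrogen, gives 1220 nM. This puts it level with compound 1, since the extra methyl gives a 1.0-fold lower number from compound 1 to compound 3 (0.02 log units; within the scatter), which cannot be told from the scatter. The one clear gap for it is to the bromo compound, a 4.2-fold higher number from compound 2 to compound 3 (0.62 log units; beyond the scatter), so it sits among the two higher numbers, on the weaker side.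

Compound 4 `Cc1ccc(C)c(NS(=O)(=O)c2ccc(N3CCNC3=O)cc2)c1` keeps the same atoms but joins them differently: 2,5-dimethylphenyl in place of 3,5-dimethylphenyl on a sulfonamide nitrogen. It has 2,5-dimethylphenyl in place of 3,5-dimethylphenyl on a sulfonamide nitrogen. Among the measured compounds shown here, no measured compound has this arrangement, so the data do not test it directly. The closest evidence is the methyl change in a 1.0-fold lower number from compound 1 to compound 3 (0.02 log units; within the scatter), while the larger measured steps involve bromo, which is absent here. The expected result is therefore no step beyond the scatter in this assay, with the estimate amounting to a 1.1-fold lower number from compound 3 to compound 4 (0.04 log units; within the scatter). For compound 4 the estimated value is 1100 nM, with an expected range from 350 nM to 3500 nM.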

Compound 4, half-maximal inhibitory concentration: 110 nM
Estimate against measurement, compound 4: 10-fold (1.00 log units) above; the measured number lies below the stated range.
By their numbers in this assay, from the lowest: compound 4; then compound 2; then compounds 3 and 1 (each within the scatter of the next).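

Moving one methyl, so that a 3,5-dimethylphenyl on the sulfonamide nitrogen becomes a 2,5-dimethylphenyl, leaves the atoms unchanged and still gives an 11-fold lower number from compound 3 to compound 4 (1.04 log units; beyond the scatter) in this assay, so on this ring the placement of the methyls matters and not only their number. The earlier compounds shown here hinted at the opposite, since a second methyl made no difference in compound 3, yet the 2,5-dimethylphenyl arrangement gives a 12-fold lower number from compound 1 to compound 4 (1.06 log units; beyond the scatter) and also outdoes the bromo compound, with a 2.6-fold lower number from compound 2 to compound 4 (0.42 log units; beyond the scatter) in the same test. Nothing measured here accounts for this gain, so the result stands as an observation without an explanation.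

Among the compounds shown here, with only one compound carrying the 2,5-dimethylphenyl, it remains open whether both methyls are needed to keep the number this low, or whether a single methyl in the new arrangement would be enough. Going by these compounds, it is equally open whether a chloro, a methoxy or a bromo could take the place of either methyl in that arrangement and give a similar result, or whether the gain belongs to methyl alone.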